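Heteroaryl swap on the piperazine methylene: compound 1 to compound 4

The source may report more compounds than this note shows. Statements on the series, on what has been measured and on what is new or still open speak of the compounds shown alone.

Measured so far in an assay on isolated protein for displacement of a labelled ligand from Gonadotropin-releasing hormone receptor (Rattus norvegicus); on this read-out lower numbers stand for stronger inhibition and higher numbers for weaker inhibition:
- compound 1 `Cc1nc(C)c(CN2CCN(c3cccc4[nH]c(-c5ccc(C(C)(C)C)cc5)nc34)CC2)o1` gives 740 nM
- compound 2 `CCc1nc(C)c(CN2CCN(c3cccc4[nH]c(-c5ccc(C(C)(C)C)cc5)nc34)CC2)s1` gives 120 nM
- compound 3 `CCc1cc(CN2CCN(c3cccc4[nH]c(-c5ccc(C(C)(C)C)cc5)nc34)CC2)n(C)n1` gives 250 nM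

Compound 1 stands highest of the three numbers; its nearest neighbour is compound 3 and its furthest is compound 2. The change to compound 4 `CCc1cc(CN2CCN(c3cccc4[nH]c(-c5ccc(C(C)(C)C)cc5)nc34)CC2)nn1C` is 5-ethyl-1-methyl-1H-pyrazol-3-yl in place of 2,4-dimethyl-1,3-oxazol-5-yl on a saturated chain carbon bound to an amine nitrogen in a ring. Among the compounds with values here, the steps that bear on it are a 3.0-fold lower number from compound 1 to compound 3 (0.47 log units; beyond the scatter), the isomeric pyrazole, and a 6.2-fold lower number from compound 1 to compound 2 (0.79 log units; beyond the scatter), both leaving the oxazole behind and both beyond the scatter. A step of similar kind, lower in this assay, is therefore expected, a 3.0-fold lower number from compound 1 to compound 4 (0.47 log units; beyond the scatter). Compound 4 is estimated at 250 nM, with a range from 100 nM to 600 nM.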

Compound 4, half-maximal inhibitory concentration: 350 nM
Compound 4: middle estimate off by 1.4-fold (0.15 log units), on the low side; the range from low to high includes it.
By their numbers in this assay, from the lowest: compound 2; then compounds 3 and 4 (each within the scatter of the next); then compound 1.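

In this assay, moving the attachment point around the ethyl-methyl pyrazole does not separate the two isomers, with a 1.4-fold higher number from compound 3 to compound 4 (0.15 log units; within the scatter). This isomer also remains clear of the oxazole, with a 2.1-fold lower number from compound 1 to compound 4 (0.33 log units; beyond the scatter), but does not match the thiazole, with a 2.9-fold higher number from compound 2 to compound 4 (0.46 log units; beyond the scatter). No data here account for these differences.

Compound 1 differs from the others in both its ring and its ethyl group, so those two contributions remain unseparated. Also open, as far as these compounds go, is how a pyridyl or phenyl ring would compare with compound 2 on the same saturated chain carbon.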